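This account rests on a few compounds, and the source may have more. Where it says the series, first, only, none or still open, it means among the compounds named here.

In an ADME assay on MT4 cells (Homo sapiens) for cytotoxicity, read by MTT assay (on this read-out higher numbers stand for lower toxicity in this test and lower numbers for higher toxicity in this test), three compounds sharing one core have been measured so far. Compound 1 (`Cc1cc(C)cc(S(=O)(=O)c2c(C(=O)Nc3cccc(O)c3)[nH]c3ccc(Cl)cc23)c1`) gives 24600 nM there, compound 2 (`Cc1cc(C)cc(S(=O)(=O)c2c(C(=O)Nc3ccc(CO)cc3)[nH]c3ccc(Cl)cc23)c1`) gives 39600 nM there, and compound 3 (`Cc1cc(C)cc(S(=O)(=O)c2c(C(=O)NCc3ccc(CO)cc3)[nH]c3ccc(Cl)cc23)c1`) gives 31100 nM there. Compound 3 thus sits among the other two, within the scatter of both. Compound 4 (`Cc1cc(C)cc(S(=O)(=O)c2c(C(=O)NCC(=O)NCc3cccc(O)c3)[nH]c3ccc(Cl)cc23)c1`) carries (3-hydroxybenzyl)carbamoyl in place of 4-(hydroxymethyl)phenyl on a saturated chain carbon bound to an amide-type nitrogen. Among the measured compounds shown here, no measured compound carries that group, so the evidence is indirect. For the measured compounds named here, the steps that bear on it are changes on the amide-type nitrogen (a 1.6-fold higher number from compound 1 to compound 2 (0.21 log units; within the scatter); a 1.3-fold higher number from compound 1 to compound 3 (0.10 log units; within the scatter); a 1.3-fold lower number from compound 2 to compound 3 (0.10 log units; within the scatter)), and all of them stay small. Taking compound 3 at 31100 nM as the anchor, no step beyond the scatter is expected in this assay in either direction. The estimated step (a 1.1-fold higher number from compound 3 to compound 4 (0.05 log units; within the scatter)) stays small. Compound 4 is expected at about 35000 nM (estimated range 15000 nM to 80000 nM).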

Compound 4, half-maximal cytotoxic concentration: > 47500 nM
Compound 4: no number, only a limit; the forecaster's own chance of this, stated with the estimate: 20%; middle value at least 1.3-fold (0.13 log units) away from the limit.
By their numbers in this assay, from the lowest: compounds 1, 3 and 2 (each within the scatter of the next). At a limit, above all of these: compound 4.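

In this assay compound 4 gives no number but a limit, so the (3-hydroxybenzyl)carbamoyl group on a saturated chain carbon bound to an amide-type nitrogen can be read only against a floor: the limit of > 47500 nM in this assay, at which 1 of the 4 values shown sits. Against the earlier compounds this reads as an at least 1.5-fold higher number from compound 3 to compound 4 (0.18 log units; that floor lies within the scatter), as an at least 1.1-fold higher number from compound 2 to compound 4 (0.07 log units; that floor lies within the scatter) and as an at least 1.9-fold higher number from compound 1 to compound 4 (0.28 log units; that floor lies within the scatter), so none of these floors sets compound 4 apart from them. What is new is that this larger group, with its added carbonyl and nitrogen, brings no measurable cytotoxicity up to that limit.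

The compounds shown leave open how far beyond the limit the true value of compound 4 lies. Also open, as far as these compounds go, is whether an amine or a carboxylic acid in place of the 3-hydroxybenzyl end would behave alike in this assay.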